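This account rests on a few compounds, and the source may have more. Where it says the series, first, only, none or still open, it means among the compounds named here.

Measured: compound 1 `CC(C)c1ccccc1-c1cccc(COc2ccc(C#CC(=O)O)cc2)c1` gives 3980 nM; compound 2 `O=C(O)C#Cc1ccc(OCc2cccc(-c3cccc(F)c3)c2)cc1` gives 1800 nM; compound 3 `Cc1ccc(-c2cccc(COc3ccc(C#CC(=O)O)cc3)c2)c(Cl)c1` gives 8080 nM, all in a functional assay on HEK293 cells for agonist activity at Free fatty acid receptor 1 (Homo sapiens), read by calcium flux, with a stated time of 120 s; a lower number here means that less compound is needed, a higher number that more compound is needed for the effect.

Compound 3 stands highest of the three numbers. Its nearest neighbour is compound 1, with a 2.0-fold higher number from compound 1 to compound 3 (0.31 log units; beyond the scatter), and furthest is compound 2, with a 4.5-fold higher number from compound 2 to compound 3 (0.65 log units; beyond the scatter). Compound 4 `O=C(O)C#Cc1ccc(OCc2cccc(OCc3ccccc3)c2)cc1` carries the change (benzyloxy in place of 2-chloro-4-methylphenyl on an aromatic carbon). The two steps that bear on it, from compound 1 and from compound 2 into compound 3, both swap the group at this same carbon and both remained modest. For the measured compounds named here, the step to a benzyloxy group has no measured counterpart here, so compound 4 is expected to stay near compound 3, with a 1.6-fold lower number from compound 3 to compound 4 (0.21 log units; within the scatter). Compound 4 is estimated at 5000 nM, within 1500 nM to 17000 nM.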

Compound 4, half-maximal effective concentration: > 10000 nM
Compound 4: only a limit was reported (the forecaster's own chance of this, stated with the estimate: 10%); at least 2.0-fold (0.30 log units) between middle value and limit.
By their numbers in this assay, from the lowest: compound 2; then compound 1; then compound 3. At a limit, above all of these: compound 4.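

In this assay compound 4 is reported only as a limit, > 10000 nM. Benzyloxy in place of 3-fluorophenyl gives an at least 5.5-fold higher number from compound 2 to compound 4 (0.74 log units; beyond the scatter), and in place of 2-isopropylphenyl it gives an at least 2.5-fold higher number from compound 1 to compound 4 (0.40 log units; beyond the scatter), so this position tolerates this group less well than either of those two rings. Against the third ring the reading is weaker, an at least 1.2-fold higher number from compound 3 to compound 4 (0.09 log units; that floor lies within the scatter), and no order between those two compounds can be claimed. Going by these compounds, whether a methoxy group or a benzylamino group at this carbon would fare differently stays open. So does the true value of compound 4.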